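One More Methyl on the Shared Core

The source may report more compounds than this note shows. Statements on the series, on what has been measured and on what is new or still open speak of the compounds shown alone.

Measured compounds:
compound 1 `COc1ccc(-c2c(C(=O)c3cc(OC)c(OC)c(OC)c3)sc3ccccc23)cc1` — 1600 nM
compound 2 `COc1ccc(-c2c(C(=O)c3cc(OC)c(OC)c(OC)c3)sc3ccccc23)cc1C` — > 10000 nM
compound 3 `COc1cc(C(=O)c2sc3ccccc3c2Nc2ccc(C)cc2)cc(OC)c1OC` — 1700 nM

All three were tested in a functional assay on Jurkat cells (Homo sapiens) for antiproliferative activity, read by MTT assay, with a stated time of 72 h; a higher number here means a weaker inhibitor, a lower number a stronger inhibitor. Compound 1 gives 1600 nM. Compound 3 gives 1700 nM. Going by the values given here, compound 2 reaches only a limit of this assay, > 10000 nM, so no number is known for it; it is the one value that sits at the limit of > 10000 nM in this assay, at which 1 of the 3 values shown sits.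

Compound 1 and compound 3 differ in the group attached to the shared core: (4-methylphenyl)amino in place of 4-methoxyphenyl on an aromatic carbon. The step this makes is a 1.1-fold higher number from compound 1 to compound 3 (0.03 log units; within the scatter). Compound 1 and compound 2 differ by a smaller change: methyl in place of hydrogen on an aromatic carbon. That change gave an at least 6.2-fold higher number from compound 1 to compound 2 (0.79 log units; beyond the scatter), and from compound 2 to compound 3 the step is an at least 5.8-fold lower number from compound 2 to compound 3 (0.76 log units; beyond the scatter).

Compound 4 `COc1cc(C(=O)c2sc3cc(C)ccc3c2Nc2ccc(C)cc2)cc(OC)c1OC` has not yet been measured. It differs from compound 3 by methyl in place of hydrogen on an aromatic carbon. Among the compounds with values here, this is the same kind of change as the one from compound 1 to compound 2, but not the same: in compound 2 the methyl sits ortho to a methoxy group and meta to a large group on a single ring, whereas in compound 4 it sits on a ring that is part of a fused system, meta to a fused ring and para to a fused ring. Because the earlier methyl gave an at least 6.2-fold higher number from compound 1 to compound 2 (0.79 log units; beyond the scatter), some loss is expected, but a smaller one at this different place, so the step from compound 3 to compound 4 is estimated at a 2.1-fold higher number from compound 3 to compound 4 (0.31 log units; beyond the scatter). Compound 4 is therefore expected to give about 3500 nM, most likely between 1200 nM and 10000 nM.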

Compound 4, half-maximal inhibitory concentration: 2500 nM
Estimate against measurement, compound 4: 1.4-fold (0.15 log units) above; the range from low to high includes it.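

In this assay, methyl in place of hydrogen on an aromatic carbon gives a 1.5-fold higher number from compound 3 to compound 4 (0.17 log units; within the scatter), so the large loss seen on the core of compound 1 does not carry over in size to the core of compound 3: the same change on two cores in this assay, an at least 6.2-fold higher number (0.79 log units; beyond the scatter) from compound 1 to compound 2 and a 1.5-fold higher number (0.17 log units; within the scatter) from compound 3 to compound 4, at least 4.2-fold (0.62 log units) apart, beyond the scatter of two such steps

This does not show whether the core or the place of the methyl accounts for the gap. Going by these compounds alone, the two methyl groups differ in both respects, with the one in compound 4 sitting on a ring that is part of a fused system, and a single pair on each core cannot separate the two. Compound 2 gives > 10000 nM, which is a limit of the assay and not a number: the limit of > 10000 nM in this assay, at which 1 of the 4 values shown sits.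

The compounds shown leave open what a methyl would do at the place it holds in compound 4 if the core of compound 1 carried it, and what it would do at the place it holds in compound 2 if the core of compound 3 carried it. They also leave open whether a chlorine atom, a methoxy group or a longer chain such as ethyl at the place of the new methyl would stay as close to compound 3.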